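The source may hold more compounds than are shown below. What is called first, only, known or untested is meant among the compounds shown, and "the series" means these compounds.

For the measured compounds named here, compound 2 `COc1cc(-c2nn(-c3cccc(NC(=O)Nc4cc(C(F)(F)F)cc(C(F)(F)F)c4)c3)cc2-c2ccncc2)ccc1Cl` is the only member of the set with a number in a functional assay on OVCAR-8 cells (Homo sapiens) for inhibition, read by sulforhodamine B assay, with a stated time of 48 h (on this read-out higher numbers stand for weaker inhibition of growth and lower numbers for stronger inhibition of growth), where compound 2 gives 3980 nM. Compound 1 `O=C(Nc1cccc(-n2cc(-c3ccncc3)c(-c3ccc(Cl)c(O)c3)n2)c1)Nc1cccc(C(F)(F)F)c1` is reported in this assay only as a limit, > 32500 nM. Going by the values given here, compound 1 and compound 2 differ in two places, so their values show only that one gives a number and the other a limit. Compound 3 `O=C(Nc1cccc(-n2cc(-c3ccncc3)c(-c3ccc(Cl)c(O)c3)n2)c1)Nc1cc(C(F)(F)F)cc(C(F)(F)F)c1` carries the change (hydrogen in place of methyl on an oxygen on an aromatic ring), methoxy to hydroxy on the 4-chloro-3-methoxyphenyl group. Among the compounds with values here, with no single-change step measured, the expected step from compound 2 to compound 3 is a 2.5-fold higher number from compound 2 to compound 3 (0.40 log units; beyond the scatter), towards weaker growth inhibition. Compound 3 is expected at 10000 nM, within 3000 nM to 32500 nM.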

Compound 3, concentration for total growth inhibition: 5920 nM
Compound 3: middle estimate off by 1.7-fold (0.23 log units), on the high side; measured number inside the range.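

Going from methoxy to hydroxy on the 4-chloro-3-methoxyphenyl group, read in this assay, gives a 1.5-fold higher number from compound 2 to compound 3 (0.17 log units; within the scatter), so hydrogen and methyl on this oxygen cannot be told apart here. With the hydroxy group held, trifluoromethyl in place of hydrogen on an aromatic carbon gives an at least 5.4-fold lower number from compound 1 to compound 3 (0.73 log units; beyond the scatter), the only step shown that lies beyond the scatter. Compound 1 enters that step only as a limit: the limit of > 32500 nM in this assay, at which 1 of the 3 values shown sits.

Going by these compounds, how an ethoxy group or an amine at this oxygen would read remains open. So does whether the methoxy-to-hydroxy result holds with a single trifluoromethyl group on the urea's aromatic ring.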